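The source may report more compounds than this note shows. Statements on the series, on what has been measured and on what is new or still open speak of the compounds shown alone.

Of the compounds shown here, two built on one shared core have been measured so far. Compound 2 `Cc1cc(Cl)ccc1NC(=O)Nc1nc(NC2CC2)cc(Sc2c[nH]c3ccccc23)n1` in a functional assay on HepG2 cells (Homo sapiens) for inhibition, with a stated time of 72 h (on this read-out lower numbers stand for stronger inhibition and higher numbers for weaker inhibition), gives 9740 nM, the lowest of the two numbers, and compound 1 `Cc1cc(Cl)ccc1NC(=O)Nc1nc(Sc2c[nH]c3ccccc23)cc(N2CCN(Cc3ccccc3)CC2)n1` gives 11700 nM in this assay, a value within the scatter of the first. Compound 3 `Cc1cc(Cl)ccc1NC(=O)Nc1nc(Sc2c[nH]c3ccccc23)cc(N2CCN(c3ccccn3)CC2)n1` differs from compound 2 in one place: 4-(pyridin-2-yl)piperazin-1-yl in place of cyclopropylamino on an aromatic carbon. Among the measured compounds shown here, no step between measured compounds is available, so no measured step tells how such a change acts. The entering group, a large ring-bearing substituent, brings compound 3 closer in build to compound 1 than to compound 2. Since compound 1 gives 11700 nM and compound 2 gives 9740 nM, the expected step of a 1.1-fold higher number from compound 2 to compound 3 (0.05 log units; within the scatter) in this assay is none beyond the scatter. Compound 3 is therefore estimated at 11000 nM, with a range from 4000 nM to 30000 nM.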

Compound 3, half-maximal inhibitory concentration: 7640 nM
The estimate for compound 3 lay 1.4-fold (0.16 log units) above the measured number; the range from low to high includes it.
By their numbers in this assay, from the lowest: compounds 3, 2 and 1 (each within the scatter of the next).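

In this assay, 4-(pyridin-2-yl)piperazin-1-yl in place of cyclopropylamino on this aromatic carbon gives a 1.3-fold lower number from compound 2 to compound 3 (0.11 log units; within the scatter), so a group of 12 heavy atoms with two rings stands here in place of one of 4 heavy atoms with no difference that the read-out can separate from the scatter. The change of pyridin-2-yl in place of benzyl on an amine nitrogen in a ring gives a 1.5-fold lower number from compound 1 to compound 3 (0.19 log units; within the scatter), so the ring-bearing group at this position can also be altered at its far end without a step beyond the scatter. No independent data on these compounds bear on why these steps stay so small.

The compounds shown leave open whether any group at this position can move the number beyond the scatter. A plain amino group, a morpholine ring or a chain ending in a carboxylic acid could test this, and the same question stands for the (1H-indol-3-yl)sulfanyl group, which all three compounds share.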